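Urea in place of amide: expected shift in cell toxicity

The source may report more compounds than this note shows. Statements on the series, on what has been measured and on what is new or still open speak of the compounds shown alone.

Compound 2 `COc1cc(-c2nn(-c3cccc(NC(=O)c4cccc(C(F)(F)F)c4)c3)cc2-c2ccncc2)ccc1Cl` is known in a functional assay on RXF 393 cells (Homo sapiens) for inhibition, read by sulforhodamine B assay, with a stated time of 48 h (on this read-out lower numbers stand for higher toxicity in this test and higher numbers for lower toxicity in this test), only as a limit of > 50000 nM rather than as a number; this is the limit of > 50000 nM in this assay, at which 1 of the 3 values shown sits. Compound 1 `COc1cc(-c2nn(-c3cccc(NC(=O)Nc4cc(C(F)(F)F)cc(C(F)(F)F)c4)c3)cc2-c2ccncc2)ccc1Cl`, which carries a urea, gives 4900 nM. Compound 3 `O=C(Nc1cccc(-n2cc(-c3ccncc3)c(-c3ccc(Cl)c(O)c3)n2)c1)Nc1ccc(Cl)c(Cl)c1` reaches only a limit of > 32500 nM. The change from compound 2 to compound 4 `COc1cc(-c2nn(-c3cccc(NC(=O)Nc4cccc(C(F)(F)F)c4)c3)cc2-c2ccncc2)ccc1Cl` is (3-(trifluoromethyl)phenyl)amino in place of 3-(trifluoromethyl)phenyl on a carbonyl carbon, so the amide becomes a urea while the 3-(trifluoromethyl)phenyl end is kept. Going by the values given here, no measured step of this kind exists; the pair compound 2 and compound 1 points towards higher toxicity for the urea, though compound 3, also a urea, stays at its limit. The step expected is an at least 3.3-fold lower number from compound 2 to compound 4 (0.52 log units; beyond the scatter), a moderate gain. Compound 4 is estimated at 15000 nM, in a range from 5000 nM to 50000 nM.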

Compound 4, concentration lethal to 50% of the cells: 4830 nM
Estimate against measurement, compound 4: 3.1-fold (0.49 log units) above; the measured number lies below the stated range.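

In this assay, the urea in place of the amide, with the 3-(trifluoromethyl)phenyl end kept, gives an at least 10-fold lower number from compound 2 to compound 4 (1.01 log units; beyond the scatter), so this single change moves the read-out. Hydrogen in place of trifluoromethyl on an aromatic carbon gives a 1.0-fold lower number from compound 1 to compound 4 (0.01 log units; within the scatter), which lies within the scatter, so the two ureas are not separated. Compound 3, also a urea, goes against any general urea effect and stands only as a limit: the limit of > 32500 nM in this assay, at which 1 of the 4 values shown sits.

The compounds shown do not separate which of the differences in compound 3 sets its limit. Also open, going by these compounds, is how an amine or a carboxylic acid in place of trifluoromethyl on the aromatic carbon would read.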